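Swapping propylamino for butylsulfanyl on a shared purine-like core

The source may hold more compounds than are shown below. What is called first, only, known or untested is meant among the compounds shown, and "the series" means these compounds.

Compound 1, `Nc1nc2c(ncn2/C=C2/CC2(CO)CO)c(=O)[nH]1`: in an ADME assay on MOLT-3 cells (Homo sapiens) for cytotoxicity, with a stated time of 7 days (on this read-out lower numbers stand for higher toxicity in this test and higher numbers for lower toxicity in this test), compound 1 gives > 20000 nM, which is a limit of the assay and not a number.
Compound 2, `CCCNc1nc(N)nc2c1ncn2/C=C1/CC1(CO)CO`: in this assay compound 2 gives "not determined" (no result reported).
Compound 3, `Nc1nc(SC2CCCC2)c2ncn(/C=C3/CC3(CO)CO)c2n1`: in this assay compound 3 gives > 20000 nM, again a limit of the assay rather than a number.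

Compound 2 therefore stands nowhere on the numbers: no single value exists for it, and the two values that do exist for its neighbours are both limits, as the limit of > 20000 nM in this assay, at which 2 of the 3 values shown sit, shows. Compound 4, `CCCCSc1nc(N)nc2c1ncn2/C=C1/CC1(CO)CO`, has not yet been measured. It differs from compound 2 in one place: butylsulfanyl in place of propylamino on an aromatic carbon.

Among the measured compounds shown here, with no measured step between any pair, no size can be read off for this change. Because the limit of > 20000 nM in this assay, at which 2 of the 3 values shown sit, puts both measured compounds at the same limit, the expectation in this assay is a step of no size beyond the scatter, with compound 4 most likely landing at that same limit. Compound 4 is estimated at 25000 nM, with a range of 8000 nM to 80000 nM.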

Compound 4, half-maximal cytotoxic concentration: > 20000 nM
Compound 4 was reported as a limit; the forecaster's own chance of this, stated with the estimate: 80%; the middle value is on the limit's open side.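

No new step can be read for compound 4: compound 4 and compound 3 both give a limit of the assay rather than a number, and compound 2 gives no number. The compounds shown leave open where the cytotoxicity of any of them lies.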